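The compounds below may be only part of what the source reports. "The series", "measured", "known", "first", "only" and "open" are said of these compounds alone.

Of the compounds shown here, two with a shared core have numbers so far in a functional assay on SK-OV-3 cells (Homo sapiens) for inhibition, read by CCK-8 assay, with a stated time of 70 h; a higher number here means a weaker inhibitor, a lower number a stronger inhibitor. Compound 1 `Clc1ccc(COc2ccc(OCCOCCNC3CCCC3)cc2)cc1` carries chloro and gives 7670 nM as its half-maximal inhibitory concentration. Compound 2 `Nc1ccc(COc2ccc(OCCOCCNC3CCCC3)cc2)cc1` carries amino in that place and gives 31700 nM as the highest of the two numbers, which makes it the weaker inhibitor of the pair. Compound 3 `COC(=O)c1ccc(COc2ccc(OCCOCCNC3CCCC3)cc2)cc1` keeps the core and differs from compound 2 at that one group, where methoxycarbonyl stands in place of amino on an aromatic carbon (methoxycarbonyl in place of amino on an aromatic carbon). Among the compounds with values here, the only measured step that bears on this change is a 4.1-fold higher number from compound 1 to compound 2 (0.62 log units; beyond the scatter) and it is modest but beyond the scatter. Within the data shown here, no measured compound carries methoxycarbonyl, so that step offers a rough size and only a tentative direction. With compound 2 at 31700 nM as the higher end of this small range, replacing amino is expected to lower the number in this assay by a modest step. The estimated change is a 2.3-fold lower number from compound 2 to compound 3 (0.35 log units; beyond the scatter) as the most likely outcome. For compound 3 the estimated range runs from 5000 nM to 35000 nM around an expected 14000 nM as the middle value.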

Compound 3, half-maximal inhibitory concentration: 6990 nM
Beside the measured number, compound 3's estimate is 2.0-fold (0.30 log units) above it, within the range that was stated.
By their numbers in this assay, from the lowest: compounds 3 and 1 (each within the scatter of the next); then compound 2.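

In this assay, methoxycarbonyl in place of amino gives a 4.5-fold lower number from compound 2 to compound 3 (0.66 log units; beyond the scatter), so compound 2 now stands apart from two differently substituted neighbours rather than from one. Methoxycarbonyl in place of chloro gives a 1.1-fold lower number from compound 1 to compound 3 (0.04 log units; within the scatter), which means that compound 1 and compound 3 cannot be told apart here, even though methoxycarbonyl places 4 heavy atoms, including a double bond outside the aromatic rings, on this aromatic carbon para to a large group. No measurement at hand explains why the amino compound stands apart from the other two.

Three groups are too few to show what separates amino from the others, although the counts do show that amino carries a hydrogen-bond donor and methoxycarbonyl carries none; dimethylamino, which has no hydrogen on its nitrogen, would show whether the number for compound 2 follows that hydrogen or the nitrogen itself. A carboxylic acid, a fluoro group or a methyl group at the same place would show whether numbers like those of compound 1 and compound 3 extend to other groups, or whether any group here gives a clearly lower number.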